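The compounds below may be only part of what the source reports. "The series", "measured", "known", "first", "only" and "open" are said of these compounds alone.

Measured compounds in an assay on isolated protein for binding affinity to corticoliberin (Rattus norvegicus); a higher number here means a weaker inhibitor, a lower number a stronger inhibitor:

compound 1 `CCCC(COC)c1c(CC)nn2c(-c3ccc(Cl)cc3Cl)nc(C)nc12`: 1.4 nM
compound 2 `CCCC(COC)c1c(CC)nn2c(-c3cc(OC)c(OC)cc3Cl)nc(C)nc12`: 2 nM

Compound 2 stands nearest compound 1, and the gap between the two numbers is within the scatter; the pair does not separate in this assay. Both share the same core and the same methoxymethyl-bearing side chain, and differ only on the aryl ring.

Compound 3 `CCCC(C)c1c(CC)nn2c(-c3cc(OC)c(OC)cc3Cl)nc(C)nc12` keeps the aryl ring of compound 2 and alters the side chain: hydrogen in place of methoxy on a saturated chain carbon, two bonds along the chain from an aromatic carbon. For the measured compounds named here, no pair of measured compounds shows a change of this kind, so the size of the step is not anchored by any measured step. The side chain is untouched between compound 1 and compound 2, which says nothing about its weight. The expectation is a small step in this assay, if any toward a higher number, and not clearly beyond the scatter. Compound 3 is estimated at 4 nM, range 1.5 nM to 12 nM. The expected step is a 2.0-fold higher number from compound 2 to compound 3 (0.30 log units; within the scatter).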

Compound 3, inhibition constant: 2.6 nM
Estimate against measurement, compound 3: 1.5-fold (0.19 log units) above; the measured number falls inside the stated range.
By their numbers in this assay, from the lowest: compounds 1, 2 and 3 (each within the scatter of the next).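

In this assay the side chain now has its first measured step: hydrogen in place of methoxy on a saturated chain carbon, two bonds along the chain from an aromatic carbon, gives a 1.3-fold higher number from compound 2 to compound 3 (0.11 log units; within the scatter), so methoxymethyl to methyl does not separate this pair. With the aryl ring of compound 2 held fixed, the methoxy is thus not required for compound 3 to read 2.6 nM, and this reading applies to that one ring only. Nothing measured on either group bears on this result.

The compounds shown leave open whether the same change reads alike with the aryl ring of compound 1. They also leave open how this carbon responds to other groups, such as a hydroxyl, an amine or a longer chain.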